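Adding a fluorine to the benzyl ring of compound 2

The source may report more compounds than this note shows. Statements on the series, on what has been measured and on what is new or still open speak of the compounds shown alone.

Of the compounds shown here, three built on one shared core have been measured in a functional assay on FM3A cells (Mus musculus) for cytotoxicity, read by cell counting, with a stated time of 2 days; a higher number here means a weaker inhibitor, a lower number a stronger inhibitor. Compound 1 `Nc1cccc(/C=C2\SC(=O)N(Cc3ccc(F)cc3)C2=O)c1` gives 140000 nM. Compound 3 `Cc1ccc(CN2C(=O)S/C(=C\c3cccc(N)c3)C2=O)cc1` differs from compound 1 only by a methyl in place of fluoro on an aromatic carbon. Compound 3 gives 158000 nM; the step of a 1.1-fold higher number from compound 1 to compound 3 (0.05 log units; within the scatter), so those two numbers lie within the scatter of each other. Compound 2 `C=C(Br)C(=O)Nc1ccc(/C=C2\SC(=O)N(Cc3ccccc3)C2=O)cc1` gives 3000 nM, the lowest number of the three, and both other compounds stand well beyond the scatter from it.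

Compound 4 `C=C(Br)C(=O)Nc1ccc(/C=C2\SC(=O)N(Cc3cccc(F)c3)C2=O)cc1` is the unmeasured partner of compound 2. The change is fluoro in place of hydrogen on an aromatic carbon. Within the data shown here, no measured pair shows hydrogen giving way to fluoro, so there is no direct precedent. Among the measured compounds shown here, the only measured step touching the same ring is a 1.1-fold higher number from compound 1 to compound 3 (0.05 log units; within the scatter), where one small group replaced another on that ring and the two numbers stayed within the scatter. On that basis a small substituent on this ring is expected to matter little. The expected step is no change at the digits printed from compound 2 to compound 4 (within the scatter), which means no movement beyond the scatter. Compound 4 is therefore estimated to give about 3000 nM, within a range from 1000 nM to 9000 nM.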

Compound 4, half-maximal inhibitory concentration: 4000 nM
For compound 4 the middle estimate is 1.3-fold (0.12 log units) below the measured one; low and high end bracket the measured number.
By their numbers in this assay, from the lowest: compounds 2 and 4 (each within the scatter of the next); then compounds 1 and 3 (each within the scatter of the next).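

In this assay, fluoro in place of hydrogen on this aromatic carbon, meta to a large group, gives a 1.3-fold higher number from compound 2 to compound 4 (0.12 log units; within the scatter), so the benzyl and 3-fluorobenzyl versions of this compound cannot be told apart by their numbers. The earlier compounds showed only one small group swapped for another on this ring, in compounds whose numbers were far higher; this pair is the first direct test of adding fluoro to a bare ring carbon, and it does so in a compound with one of the two lowest numbers shown. Nothing measured explains why the two numbers lie so close, and no supporting data on this point are available.

As far as these compounds go, a single fluorine is a very small probe, so it remains open whether a methoxy group, an amine, a carboxylic acid or a longer chain such as butoxy on this same carbon would also leave the number within the scatter. Fluoro on the other carbons of this ring also remains an open question, since this pair speaks for one ring carbon only.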